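The source may report more compounds than this note shows. Statements on the series, on what has been measured and on what is new or still open speak of the compounds shown alone.

Three measured compounds share one core, and the question is how a fourth will behave in a functional assay on ACHN cells (Homo sapiens) for cytotoxicity, read by sulforhodamine B assay, with a stated time of 72 h; a higher number here means a weaker inhibitor of growth, a lower number a stronger inhibitor of growth. Compound 1 `O=C(Nc1ccccc1C(F)(F)F)C1CCc2ccccc2N1` gives 57600 nM in this assay. Compound 2 `O=C(Nc1ccccc1C(F)(F)F)C1CCc2ccccc2N1C(=O)c1ccccc1` gives 8090 nM in this assay, and compound 3 `O=C(Nc1ccccc1O)C1CCc2ccccc2N1C(=O)c1ccccc1` gives 4260 nM in this assay. Compound 3 has the lowest number of the three, though its gap to compound 2 is within the scatter, so no order between those two is drawn.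

Two measured steps set the frame. From compound 2 to compound 1 the change is hydrogen in place of benzoyl on a nitrogen on an aromatic ring in a ring and the step is a 7.1-fold higher number from compound 2 to compound 1 (0.85 log units; beyond the scatter). From compound 2 to compound 3 the change is hydroxy in place of trifluoromethyl on an aromatic carbon, with a step of a 1.9-fold lower number from compound 2 to compound 3 (0.28 log units; within the scatter).

Compound 4 `O=C(Nc1ccccc1O)C1CCc2ccccc2N1` has not yet been measured. It differs from compound 3 by hydrogen in place of benzoyl on a nitrogen on an aromatic ring in a ring, the same change that was made from compound 2 to compound 1, at a place described in the same words. The two cores on which this change is made differ by hydroxy in place of trifluoromethyl on an aromatic carbon. Since the replacement of benzoyl by hydrogen is repeated on a closely related core, compound 4 is expected to show a 6.6-fold higher number from compound 3 to compound 4 (0.82 log units; beyond the scatter) because the measured pair gave a 7.1-fold higher number from compound 2 to compound 1 (0.85 log units; beyond the scatter). On that basis compound 4 is estimated at 28000 nM, with a likely range from 8000 nM to 90000 nM.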

Compound 4, concentration for 50% growth inhibition: 3990 nM
Compound 4: middle estimate off by 7.0-fold (0.85 log units), on the high side; the whole stated range lies above it.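

In this assay, replacing benzoyl with hydrogen on the core bearing hydroxy gives a 1.1-fold lower number from compound 3 to compound 4 (0.03 log units; within the scatter), so the loss seen on the core bearing trifluoromethyl did not carry over: the same change on two cores in this assay, a 7.1-fold higher number (0.85 log units; beyond the scatter) from compound 2 to compound 1 and a 1.1-fold lower number (0.03 log units; within the scatter) from compound 3 to compound 4, 7.6-fold (0.88 log units) apart, beyond the scatter of two such steps. Read along the other change, hydroxy in place of trifluoromethyl gives a 14-fold lower number from compound 1 to compound 4 (1.16 log units; beyond the scatter) when the ring nitrogen bears hydrogen, a much larger step than the one seen when it bears benzoyl: the same change on two cores in this assay, a 1.9-fold lower number (0.28 log units; within the scatter) from compound 2 to compound 3 and a 14-fold lower number (1.16 log units; beyond the scatter) from compound 1 to compound 4, 7.6-fold (0.88 log units) apart, beyond the scatter of two such steps. Across these four compounds the two changes therefore do not add up independently, since the effect of each depends on the group present at the other place, but this rests on a single set of two cores and does not show why the steps differ or give a rule for other members of the series.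

As far as these compounds go, it remains open whether a smaller acyl group such as acetyl, or a methyl group, on the ring nitrogen would follow the core bearing hydroxy or the core bearing trifluoromethyl. From the compounds shown here alone, it is equally open whether a methoxy group, an amine or a fluorine on the aromatic carbon would behave like hydroxy or like trifluoromethyl when the ring nitrogen bears hydrogen.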